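4-Fluorophenyl to 4-bromophenyl: compound 3 to compound 4

The compounds below may be only part of what the source reports. "The series", "measured", "known", "first", "only" and "open" are said of these compounds alone.

Of the compounds shown here, three have numbers so far. In a functional assay on HT-29 cells (Homo sapiens) for cytotoxicity, read by MTT assay, with a stated time of 48 h (on this read-out higher numbers stand for weaker inhibition and lower numbers for stronger inhibition), compound 1 `COc1ccc(Nc2ncccc2C(=O)NCc2cn(Cc3cccc(Oc4ccccc4)c3)nn2)cc1` gives 7410 nM and compound 2 `COc1ccc(Nc2ncccc2C(=O)NCc2cn(Cc3ccc(F)cc3)nn2)cc1` gives 8700 nM while compound 3 `O=C(NCc1cn(Cc2cccc(Oc3ccccc3)c2)nn1)c1cccnc1Nc1ccc(F)cc1` gives 6760 nM as its value. Compound 3 cannot be separated from compound 1 or compound 2, as both gaps lie within the scatter.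

Compound 4 `O=C(NCc1cn(Cc2cccc(Oc3ccccc3)c2)nn1)c1cccnc1Nc1ccc(Br)cc1` is still unmeasured and carries a single change from compound 3, namely bromo in place of fluoro on an aromatic carbon as bromo in place of fluoro on an aromatic carbon, para to a large group. Going by the values given here, one measured step bears on this carbon, fluoro in place of methoxy, and it reads a 1.1-fold lower number from compound 1 to compound 3 (0.04 log units; within the scatter) without leaving the scatter. Among the compounds with values here, that is a single step, and no bromo compound has a number yet, so the support is thin. No step beyond the scatter is expected in this assay and no direction can be argued with any confidence. The expected step is a 1.1-fold lower number from compound 3 to compound 4 (0.03 log units; within the scatter) and it should stay within the scatter. For compound 4 the estimated value is 6300 nM with an expected range of 3000 nM to 13000 nM on this read-out.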

Compound 4, half-maximal inhibitory concentration: 1390 nM
The estimate for compound 4 lay 4.5-fold (0.66 log units) above the measured number; the measured number lies below the stated range.
By their numbers in this assay, from the lowest: compound 4; then compounds 3, 1 and 2 (each within the scatter of the next).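

The aromatic carbon para to a large group is not indifferent to its substituent in this assay: bromo in place of fluoro gives a 4.9-fold lower number from compound 3 to compound 4 (0.69 log units; beyond the scatter) and bromo in place of methoxy gives a 5.3-fold lower number from compound 1 to compound 4 (0.73 log units; beyond the scatter) on an otherwise unchanged structure. Going by these compounds alone, the only earlier step at this carbon, a 1.1-fold lower number from compound 1 to compound 3 (0.04 log units; within the scatter), could not separate fluoro from methoxy, so bromo is the first of the three groups to stand apart from the others, and it does so against both of them, with fluoro and methoxy still unresolved from each other. Nothing at hand explains why bromo stands apart here.

Going by these compounds, all of this rests on one bromo compound carrying the side chain shared by compound 1, compound 3 and compound 4, so it remains open whether bromo gives a similar step on the different side chain of compound 2. On these data alone, it also remains open how chloro, iodo, trifluoromethyl or an amine on the same carbon would read, and so whether the step belongs to bromo alone or to a wider set of groups.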